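Adding a bromo to the 3-aminophenyl compound

A few compounds are considered here, and "the series" means these few. Any claim that something is new, unique, unknown or untested is made for them only; others in the source may bear on it.

Measured in a functional assay on HCT-116 cells (Homo sapiens) for cytotoxicity, read by MTT assay, with a stated time of 72 h; a lower number here means a stronger inhibitor, a higher number a weaker inhibitor:
- compound 1 `COc1ccc(Nc2nc3ccccc3nc2S(=O)(=O)c2ccccc2)cc1`: 2420 nM
- compound 2 `Nc1ccc(Nc2nc3ccccc3nc2S(=O)(=O)c2ccccc2)cc1`: 10800 nM
- compound 3 `Nc1cccc(Nc2nc3ccccc3nc2S(=O)(=O)c2ccccc2)c1`: 1540 nM

Compound 3 stands at the low end of these numbers: a 7.0-fold lower number from compound 2 to compound 3 (0.85 log units; beyond the scatter), whereas a 1.6-fold lower number from compound 1 to compound 3 (0.20 log units; within the scatter) stays within the scatter. Compound 4 `Nc1cccc(Nc2nc3ccccc3nc2S(=O)(=O)c2ccc(Br)cc2)c1` turns a phenyl into a 4-bromophenyl, with bromo in place of hydrogen on an aromatic carbon. The measured steps all changed the group on nitrogen, and the clearest, a 4.5-fold higher number from compound 1 to compound 2 (0.65 log units; beyond the scatter), was modest. None alters this phenyl, so they indicate only a typical size, and no change beyond the scatter is expected in this assay. The estimated step is a 1.1-fold lower number from compound 3 to compound 4 (0.04 log units; within the scatter). Compound 4 is expected at 1400 nM, within an estimated range of 450 nM to 4500 nM.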

Compound 4, half-maximal inhibitory concentration: 3280 nM
The estimate for compound 4 lay 2.3-fold (0.37 log units) below the measured number; the measured number falls inside the stated range.
By their numbers in this assay, from the lowest: compounds 3, 1 and 4 (each within the scatter of the next, the first and the last beyond it); then compound 2.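

Changing the phenyl to a 4-bromophenyl gives a 2.1-fold higher number from compound 3 to compound 4 (0.33 log units; beyond the scatter). Among the compounds shown here, none of the earlier steps touched this phenyl, and this one shows that the number responds to a change here: a single bromo, para to a large group, moves it beyond the scatter, towards weaker inhibition. The data shown offer no measured explanation for this shift. Going by these compounds, whether any group in this place raises the number, or bromo in particular, stays open, since a fluoro, a methoxy or an amine here could behave differently. Also open, on these data alone, is whether the same bromo would have a similar effect with a different group on the nitrogen.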